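The compounds below may be only part of what the source reports. "The series", "measured", "known", "first", "only" and "open" are said of these compounds alone.

The measured compounds are compound 1 `Cc1ccc(-c2nnc(N3CCN(C(=O)CN4CCN(c5ccccc5Cl)CC4)CC3)nc2-c2ccc(C)cc2)cc1` with 859000 nM, compound 2 `COc1cccc(N2CCN(CC(=O)N3CCN(c4nnc(-c5ccc(C)cc5)c(-c5ccc(C)cc5)n4)CC3)CC2)c1` with 867000 nM, and compound 3 `COc1ccc(-c2nnc(N3CCN(C(=O)CN4CCN(c5ccccc5Cl)CC4)CC3)nc2-c2ccc(OC)cc2)cc1`. For compound 3 only a limit is recorded.

All three were tested in a functional assay on MCF7 cells (Homo sapiens) for cytotoxicity, read by MTT assay, with a stated time of 24 h; on this read-out higher numbers stand for weaker inhibition and lower numbers for stronger inhibition. In this assay compound 1 gives 859000 nM and compound 2 gives 867000 nM. Compound 3 reaches only a limit of the assay, > 814000 nM, which is the limit of > 814000 nM in this assay, at which 1 of the 3 values shown sits. Compound 2 differs from compound 1 by 3-methoxyphenyl in place of 2-chlorophenyl on an amine nitrogen in a ring, and this change gave a 1.0-fold higher number from compound 1 to compound 2 (0.00 log units; within the scatter). How the core of compound 3 differs from the core of compound 1 is not broken down here. Within the data shown here, compound 4 `COc1ccc(-c2nnc(N3CCN(C(=O)CN4CCN(c5cccc(OC)c5)CC4)CC3)nc2-c2ccc(OC)cc2)cc1` has not yet been measured; it differs from compound 3 by 3-methoxyphenyl in place of 2-chlorophenyl on an amine nitrogen in a ring, the same change at the same place as the one from compound 1 to compound 2. Because that earlier change gave a 1.0-fold higher number from compound 1 to compound 2 (0.00 log units; within the scatter), the step from compound 3 to compound 4 is expected to be similarly small, a step that the limit leaves unreadable from compound 3 to compound 4. Compound 4 is therefore expected to remain at or near a limit, with an estimate of 900000 nM, between 500000 nM and 2000000 nM.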

Compound 4, half-maximal inhibitory concentration: > 821000 nM
Compound 4 ended at the assay's limit (the forecaster's own chance of this, stated with the estimate: 70%); the middle value does not contradict the limit.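

No new step can be read from compound 3 to compound 4 in this assay: both compounds are recorded only as limits, so their difference has no readable size. The compounds shown leave open where the true values of compound 3 and compound 4 lie, and whether 3-methoxyphenyl in place of 2-chlorophenyl changes anything on this core.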